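Indole enone nitriles tested for prostate cancer cell cytotoxicity

The source may hold more compounds than are shown below. What is called first, only, known or untested is meant among the compounds shown, and "the series" means these compounds.

Compound 1 `N#C/C(=C\c1cn(Cc2ccc(Cl)cc2)c2ccccc12)C(=O)c1c[nH]c2ccccc12` gives > 50000 nM in a functional assay on PC-3 cells (Homo sapiens) for cytotoxicity, read by WST assay, with a stated time of 48 h (a higher number here means a weaker inhibitor, a lower number a stronger inhibitor), which is a limit.
Compound 2 `COc1ccc2[nH]cc(/C=C(\C#N)C(=O)c3c[nH]c4ccc(OC)cc34)c2c1` gives > 50000 nM in this assay, which is a limit.
Compound 3 `COc1ccc(Cn2cc(/C=C(\C#N)C(=O)c3c[nH]c4cc(OC)ccc34)c3ccccc32)cc1` gives > 50000 nM in this assay, which is a limit.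

Compound 2 therefore stands only at a limit, with no number behind it, and it is not alone there: the limit of > 50000 nM in this assay, at which 3 of the 3 values shown sit. The step to compound 4 `COc1ccc2[nH]cc(/C=C(\C#N)C(=O)c3c[nH]c4ccccc34)c2c1` is a single change: hydrogen in place of methoxy on an aromatic carbon. Within the data shown here, no measured pair shows the effect of such a change here. With every reading at the limit, the expected step in this assay is none beyond the scatter, in no particular direction. The change from compound 2 to compound 4 is thus expected to amount to a step that the limit leaves unreadable from compound 2 to compound 4. Compound 4 is expected at 80000 nM, in a range from 20000 nM to 300000 nM, and most probably only a limit will again be reported.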

Compound 4, half-maximal inhibitory concentration: 30500 nM
Compound 4: the middle estimate sits 2.6-fold (0.42 log units) above what was measured; measured number inside the range.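

In this assay compound 4 is the only compound shown that reads as a number, 30500 nM. Among these compounds, this aromatic carbon is the first place where a single change leaves the limit. Hydrogen in place of methoxy gives an at least 1.6-fold lower number from compound 2 to compound 4 (0.21 log units; that floor lies within the scatter). That is a floor and not a measured size, since compound 2 stands only at a limit: the limit of > 50000 nM in this assay, at which 3 of the 4 values shown sit.

From the compounds shown here alone, how large the step truly is stays open. So does whether another group on this carbon, such as fluorine, an amine or a carboxylic acid, would read as a number too.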